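Swapping Pentyl for 4-Methylphenyl on the Ring Nitrogen

This account rests on a few compounds, and the source may have more. Where it says the series, first, only, none or still open, it means among the compounds named here.

Compound 1 `CCc1cccc(NC(=O)c2cccc(/C=C3\CC(=O)N(Cc4ccccc4)C3=O)c2)c1` in an ADME assay on SW480 cells (Homo sapiens) for cytotoxicity, read by MTT assay, with a stated time of 72 h; a lower number here means a stronger inhibitor, a higher number a weaker inhibitor: 91500 nM. Compound 2 `CCCCCN1C(=O)C/C(=C\c2cccc(C(=O)Nc3cccc(CC)c3)c2)C1=O` in this assay: 83300 nM. Compound 3 `CCCCCN1C(=O)C/C(=C\c2cccc(C(=O)NCCCC)c2)C1=O` in this assay reaches only a limit of the assay, > 100000 nM.

Compound 2 holds the lowest of the two real numbers, with compound 1 nearest, a 1.1-fold lower number from compound 1 to compound 2 (0.04 log units; within the scatter). Compound 3 sits at the limit of > 100000 nM in this assay, at which 1 of the 3 values shown sits. Compound 4 `CCc1cccc(NC(=O)c2cccc(/C=C3\CC(=O)N(c4ccc(C)cc4)C3=O)c2)c1` differs from compound 2 by 4-methylphenyl in place of pentyl on an amide-type nitrogen in a ring. Going by the values given here, the one step already measured at that same nitrogen, a 1.1-fold lower number from compound 1 to compound 2 (0.04 log units; within the scatter), stayed within the scatter, and an at least 1.2-fold higher number from compound 2 to compound 3 (0.07 log units; that floor lies within the scatter) at the other amide nitrogen did too. The step expected here, a 1.0-fold higher number from compound 2 to compound 4 (0.01 log units; within the scatter), is therefore none beyond the scatter. Compound 4 is estimated at 85000 nM, between 40000 nM and 160000 nM.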

Compound 4, half-maximal inhibitory concentration: 65300 nM
Compound 4: middle estimate off by 1.3-fold (0.11 log units), on the high side, and the stated range covers the measured number.
By their numbers in this assay, from the lowest: compounds 4, 2 and 1 (each within the scatter of the next). At a limit, above all of these: compound 3.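

With 4-methylphenyl on the amide-type nitrogen in a ring, this position now carries a third kind of group, and in this assay the change gives a 1.3-fold lower number from compound 2 to compound 4 (0.11 log units; within the scatter) and, against benzyl, a 1.4-fold lower number from compound 1 to compound 4 (0.15 log units; within the scatter) without leaving the scatter. Pentyl, benzyl and 4-methylphenyl therefore cannot be told apart at this nitrogen. Nothing measured here bears on why this is so. Going by these compounds, whether an amine, a carboxylic acid or a longer chain at this nitrogen would move the number beyond the scatter stays open.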